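Ring methoxy removal in the lactone and diol series

The source may report more compounds than this note shows. Statements on the series, on what has been measured and on what is new or still open speak of the compounds shown alone.

Among the compounds with values here, the compounds share a six-membered non-aromatic ring of carbon only that bears a hydroxy group, a methyl group and a large group. Compound 2 `COC1=C(OC)[C@H](O)[C@H](C/C=C(\C)CC/C=C(\C)C[C@@H]2C[C@@H](C)C(=O)O2)[C@@H](C)C1=O` carries two methoxy groups on that ring; in a functional assay on A549 cells (Homo sapiens) for inhibition, read by sulforhodamine B assay, with a stated time of 48 h (a higher number here means a weaker inhibitor of growth, a lower number a stronger inhibitor of growth), compound 2 gives 14100 nM. Compound 1 `COC1=C[C@H](O)[C@H](C/C=C(\C)CC/C=C(\C)C[C@@H]2C[C@@H](C)C(=O)O2)[C@@H](C)C1=O` differs from it by hydrogen in place of methoxy on a double-bonded ring carbon. In this assay compound 1 gives only a limit, > 30000 nM. The step of an at least 2.1-fold higher number from compound 2 to compound 1 (0.32 log units; beyond the scatter) is thus a loss of growth inhibition of at least that size, fixed by the limit of > 30000 nM in this assay, at which 1 of the 3 values shown sits.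

Compound 3 `COC1=C(OC)[C@H](O)[C@H](C/C=C(\C)CC/C=C(\C)C[C@H](O)/C=C(\C)CO)[C@@H](C)C1=O` keeps both methoxy groups and alters the large group: a group of 7 heavy atoms (5 carbon, 2 oxygen; no ring) in place of a group of 7 heavy atoms (5 carbon, 2 oxygen; one five-membered non-aromatic ring with 1 hetero atom), on a saturated chain carbon bound to a double-bonded chain carbon. In this assay compound 3 gives 12000 nM. The step of a 1.2-fold lower number from compound 2 to compound 3 (0.07 log units; within the scatter) lies within the scatter, so the two versions of the large group are treated as equivalent here.

Compound 4 `COC1=C[C@H](O)[C@H](C/C=C(\C)CC/C=C(\C)C[C@H](O)/C=C(\C)CO)[C@@H](C)C1=O` is not yet measured. Against compound 3 it shows (hydrogen in place of methoxy on a double-bonded ring carbon), the same change as that from compound 2 to compound 1, at a place described in the same words. The expected step is a 2.5-fold higher number from compound 3 to compound 4 (0.40 log units; beyond the scatter), resting on an at least 2.1-fold higher number from compound 2 to compound 1 (0.32 log units; beyond the scatter) and on the unchanged number across a 1.2-fold lower number from compound 2 to compound 3 (0.07 log units; within the scatter). Compound 4 is therefore expected near 30000 nM. The estimate for compound 4 spans 15000 nM to 70000 nM, with a fair chance that this assay reports only a limit.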

Compound 4, concentration for 50% growth inhibition: > 30000 nM
Compound 4 ended at the assay's limit (the forecaster's own chance of this, stated with the estimate: 55%); the middle value lies on the limit itself.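

In this assay compound 4 gives > 30000 nM, which is a limit of the assay and not a number. Hydrogen in place of methoxy on a double-bonded ring carbon gives an at least 2.5-fold higher number from compound 3 to compound 4 (0.39 log units; beyond the scatter), so the loss of growth inhibition seen on the lactone-bearing core also appears on the core with the open chain, and the two steps cannot be told apart in size: the same change on two cores in this assay, an at least 2.1-fold higher number (0.32 log units; beyond the scatter) from compound 2 to compound 1 and an at least 2.5-fold higher number (0.39 log units; beyond the scatter) from compound 3 to compound 4; the limit leaves it open whether they differ What this does not show is the true size of the loss on either core, and the step between the two compounds that lack this methoxy group, compound 1 and compound 4, cannot be read: the limit of > 30000 nM in this assay, at which 2 of the 4 values shown sit.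

The compounds shown leave open whether the loss is specific to methoxy at this place, as hydrogen is the only replacement here; an ethoxy group or a chlorine atom on the same ring carbon would separate these readings. They also leave open what the remaining methoxy group on the neighbouring ring atom contributes, and whether a hydroxy group there would keep the growth inhibition of compound 2 and compound 3.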